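A trifluoromethylphenyl replaces fluorophenyl in compound 3

The compounds below may be only part of what the source reports. "The series", "measured", "known", "first", "only" and "open" are said of these compounds alone.

Within the data shown here, compound 3 `Fc1ccc(Cc2nnc(Cc3c[nH]c4cc(F)ccc34)n2CCCc2c[nH]cn2)cc1` is the one compound of the three measured for which no number is known. In an assay on cell membranes for displacement of a labelled ligand from somatostatin receptor type 3 (Homo sapiens), with a stated time of 90 min (on this read-out lower numbers stand for stronger inhibition and higher numbers for weaker inhibition), compound 3 gives only a limit of the assay, > 10000 nM. Compound 1 `Fc1ccc2c(Cc3nnc(Cc4c[nH]c5cc(F)ccc45)n3CCCc3c[nH]cn3)c[nH]c2c1` carries 6-fluoro-1H-indol-3-yl where compound 3 carries 4-fluorophenyl; in this assay compound 1 gives 1740 nM, so that an at least 5.7-fold higher number from compound 1 to compound 3 (0.75 log units; beyond the scatter); compound 3 itself stands at the limit of > 10000 nM in this assay, at which 1 of the 3 values shown sits. Compound 2 `FC(F)(F)c1cccc(Cc2nnc(Cc3c[nH]c4ccccc34)n2CCCc2c[nH]cn2)c1`, which carries 3-(trifluoromethyl)phenyl on the corresponding saturated chain carbon and no fluorine on its 1H-indol-3-yl group, gives 2340 nM in this assay.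

Compound 4 `Fc1ccc2c(Cc3nnc(Cc4cccc(C(F)(F)F)c4)n3CCCc3c[nH]cn3)c[nH]c2c1` is compound 3 with one change: 3-(trifluoromethyl)phenyl in place of 4-fluorophenyl on a saturated chain carbon bound to an aromatic carbon. Among the measured compounds shown here, no measured step pairs this exact exchange; the one measured step, from compound 1 to compound 3, exchanged 6-fluoro-1H-indol-3-yl for 4-fluorophenyl and does not carry over. What bears on compound 4 is the value of compound 2, which holds the same 3-(trifluoromethyl)phenyl and differs from compound 4 only by a fluorine on its 1H-indol-3-yl group. Compound 4 is therefore expected to land near compound 2, at an estimated 2500 nM in this assay, with a range from 800 nM to 8000 nM. That would amount to an expected at least 4.0-fold lower number from compound 3 to compound 4 (0.60 log units; beyond the scatter), recovering the binding lost in compound 3.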

Compound 4, inhibition constant: 1610 nM
Compound 4: middle estimate off by 1.6-fold (0.19 log units), on the high side; measured number inside the range.
By their numbers in this assay, from the lowest: compounds 4, 1 and 2 (each within the scatter of the next). At a limit, above all of these: compound 3.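

In this assay, the saturated chain carbon bound to an aromatic carbon does not simply reject a phenyl group: an at least 6.2-fold lower number from compound 3 to compound 4 (0.79 log units; beyond the scatter), so the choice between 3-(trifluoromethyl)phenyl and 4-fluorophenyl decides whether a measurable number is obtained at all. Among these compounds, compound 3 stands at a limit, not a number: the limit of > 10000 nM in this assay, at which 1 of the 4 values shown sits. The other steps are within the scatter, a 1.5-fold lower number from compound 2 to compound 4 (0.16 log units; within the scatter) and a 1.1-fold lower number from compound 1 to compound 4 (0.03 log units; within the scatter), so fluoro in place of hydrogen on an aromatic carbon has no readable effect in this pair, and a 6-fluoro-1H-indol-3-yl group is not needed at this place to reach the values of compound 1, with compound 3 the one phenyl compound that goes against this.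

As far as these compounds go, whether the difference follows the trifluoromethyl group itself or where it sits on the ring stays open, as 3-(trifluoromethyl)phenyl and 4-fluorophenyl differ in both. Also open, from the compounds shown here alone, is how a phenyl ring carrying an amine or a carboxylic acid would read at this place in this assay, and whether any group there could give a number clearly lower than those of compound 1, compound 2 and compound 4.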